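This account rests on a few compounds, and the source may have more. Where it says the series, first, only, none or still open, it means among the compounds named here.

Measured in an ADME assay on CCRF-HSB-2 cells (Homo sapiens) for cytotoxicity, with a stated time of 7 days; a lower number here means that less compound is tolerated, a higher number that more compound is tolerated:
- Compound 1 `CCOc1nc(N)nc2c1ncn2/C=C1/CC1(CO)CO`: > 20000 nM
- Compound 2 `COCCOc1nc(N)nc2c1ncn2/C=C1/CC1(CO)CO`: > 20000 nM

Compound 1 stands only at a limit, > 20000 nM.

Compound 2 also stands only at a limit, > 20000 nM.

Among the compounds with values here, the series so far is the limit of > 20000 nM in this assay, at which 2 of the 2 values shown sit. Compound 3 `Nc1nc(OCc2ccccc2)c2ncn(/C=C3/CC3(CO)CO)c2n1` follows from compound 2 by phenyl in place of methoxymethyl on a saturated chain carbon bound to an oxygen on an aromatic ring. Within the data shown here, the only measured step, a step that the two limits leave unreadable from compound 1 to compound 2, gives no size, so no step beyond the scatter is expected in this assay. The estimated change is a number no higher from compound 2 to compound 3 (the limit leaves the size open). Compound 3 is expected at 20000 nM, with an estimated range of 7000 nM to 40000 nM.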

Compound 3, half-maximal cytotoxic concentration: > 20000 nM
Compound 3: no number, only a limit; the forecaster's own chance of this, stated with the estimate: 60%; the middle value lies on the limit itself.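

No step can be read among compound 1, compound 2 and compound 3 in this assay, since each stands only at a limit: the limit of > 20000 nM in this assay, at which 3 of the 3 values shown sit.

The compounds shown leave open where each half-maximal cytotoxic concentration actually lies, and whether benzyloxy in place of 2-methoxyethoxy changes it at all.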